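Extending the Acetyl of Compound 1 with Propylamino

This account rests on a few compounds, and the source may have more. Where it says the series, first, only, none or still open, it means among the compounds named here.

Two measured compounds frame this step. Compound 1 `CC(=O)Nc1ccc(C2=NNC(=O)CC2)cc1` gives 1 ug/mL in a functional assay for inhibition, with Homo sapiens as the target (a lower number here means that less compound is needed, a higher number that more compound is needed for the effect), the lowest of the two numbers recorded. Within the data shown here, compound 2 `CC1CC(c2ccc(N)cc2)=NNC1=O` gives 43.8 ug/mL in this assay, a far higher number that lies beyond the scatter; no single-point step between compound 1 and compound 2 is described, so only the two values themselves can be compared.

Compound 3 `CCCNCC(=O)Nc1ccc(C2=NNC(=O)CC2)cc1` has not yet been measured. It differs from compound 1 in one place: propylamino in place of hydrogen on a saturated chain carbon bound to a carbonyl carbon. The acetyl of compound 1 thus becomes ((propylamino)methyl)carbonyl.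

Among the measured compounds shown here, with no comparable step among the measured compounds, the expected outcome rests on the anchor value of compound 1 alone. A small step is expected, toward a somewhat higher number, of size a 2.0-fold higher number from compound 1 to compound 3 (0.30 log units; within the scatter). Compound 3 is therefore estimated at 2 ug/mL in this assay, within a range from 0.5 ug/mL to 8 ug/mL.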

Compound 3, half-maximal effective concentration: about 46.4 ug/mL
Compound 3: the middle estimate sits 23-fold (1.37 log units) below what was measured, outside the stated range (above it).
By their numbers in this assay, from the lowest: compound 1; then compounds 2 and 3 (each within the scatter of the next).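

Among these compounds, compound 3 gives the first single-change comparison at this position: in this assay, propylamino in place of hydrogen on a saturated chain carbon bound to a carbonyl carbon produces a 46-fold higher number from compound 1 to compound 3 (1.67 log units; beyond the scatter). The earlier compounds shown here could not show that this carbon of the acetyl is sensitive to change, yet on the core of compound 1 this one replacement, giving ((propylamino)methyl)carbonyl, is enough to mean that far more compound is needed for the effect. No available evidence bears on why the step is this large.

Going by these compounds, whether the step follows from the nitrogen of propylamino or from the length of the chain stays open. What a plain butyl chain, a dimethylamino group or a hydroxyl on that same carbon would give in this assay also remains an open question.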